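The compounds below may be only part of what the source reports. "The series", "measured", "known", "first", "only" and "open" are said of these compounds alone.

Measured compounds:
Compound 1, `CCCCCCCCOP(=O)(O)OCCSC(=S)N1CCCC1`, 47100 nM
Compound 2, `CCCCCCCCCCOP(=O)(O)OCCSC(=S)N1CCCC1`, 46100 nM
Compound 3, `CCCCCCCCCCOP(=O)(O)OCCSC(=S)N1CCN(C)CC1`, 82300 nM

All three were tested in a functional assay on DU-145 cells (Homo sapiens) for inhibition, read by MTT assay, with stated times of 18 h and 4 h; on this read-out higher numbers stand for weaker inhibition and lower numbers for stronger inhibition. Compound 2 and compound 1 differ by one change, (hydrogen in place of ethyl on a saturated chain carbon, eight bonds along the chain from an oxygen on an unsaturated carbon), and this gave a 1.0-fold higher number from compound 2 to compound 1 (0.01 log units; within the scatter). Compound 2 and compound 3 differ in their cores, (4-methylpiperazin-1-yl in place of pyrrolidin-1-yl on a thiocarbonyl carbon), which gave a 1.8-fold higher number from compound 2 to compound 3 (0.25 log units; within the scatter). Compound 3 carries the highest of the three numbers, but its gaps to the other two fall inside the scatter.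

The unmeasured compound 4, `CCCCCCCCOP(=O)(O)OCCSC(=S)N1CCN(C)CC1`, is related to compound 3 by hydrogen in place of ethyl on a saturated chain carbon, eight bonds along the chain from an oxygen on an unsaturated carbon. This is the same change that turns compound 2 into compound 1, and the place of the change reads the same in both pairs. Since that earlier step, a 1.0-fold higher number from compound 2 to compound 1 (0.01 log units; within the scatter), left the number essentially unmoved, the expectation for compound 4 rests on that single precedent and on the value of compound 3, 82300 nM. The step from compound 3 to compound 4 is thus expected to be a 1.0-fold lower number from compound 3 to compound 4 (0.00 log units; within the scatter). Compound 4 is therefore estimated at 82000 nM, with a range from 41000 nM to 165000 nM, given the weak inhibition seen across the series.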

Compound 4, half-maximal inhibitory concentration: > 100000 nM
Compound 4: a limit, no number (the forecaster's own chance of this, stated with the estimate: 15%); middle value at least 1.2-fold (0.08 log units) from the limit.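

In this assay compound 4 gives > 100000 nM, which is a limit of the assay and not a number. Putting hydrogen in place of ethyl on the core that carries 4-methylpiperazin-1-yl gives an at least 1.2-fold higher number from compound 3 to compound 4 (0.08 log units; that floor lies within the scatter), so the reading does not rule out that this change carries over with the same small size it had on the pyrrolidin-1-yl core, but it does not prove that either: the same change on two cores in this assay, a 1.0-fold higher number (0.01 log units; within the scatter) from compound 2 to compound 1 and an at least 1.2-fold higher number (0.08 log units; that floor lies within the scatter) from compound 3 to compound 4; the limit leaves it open whether they differ The same holds for 4-methylpiperazin-1-yl in place of pyrrolidin-1-yl, which at the shorter chain gives an at least 2.1-fold higher number from compound 1 to compound 4 (0.32 log units; beyond the scatter), so the floor of this step lies beyond the scatter while the earlier step lies within it, yet a real dependence on chain length is not shown: the same change on two cores in this assay, a 1.8-fold higher number (0.25 log units; within the scatter) from compound 2 to compound 3 and an at least 2.1-fold higher number (0.32 log units; beyond the scatter) from compound 1 to compound 4; the limit leaves it open whether they differ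

How large the true steps to compound 4 are stays open, since only a floor can be read: the limit of > 100000 nM in this assay, at which 1 of the 4 values shown sits. The compounds shown also leave open how a longer chain at the same place, or a morpholine or piperidine on the thiocarbonyl carbon, would read in this assay.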